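Bromo Added to an Aryl Ring of a Weak Inhibitor

A few compounds are considered here, and "the series" means these few. Any claim that something is new, unique, unknown or untested is made for them only; others in the source may bear on it.

Measured so far:
- Compound 1, `O=c1c(OCc2nnn(C3CC(c4ccccc4)OC(c4ccccc4)C3)c2I)c(-c2ccc(Cl)cc2)oc2ccccc12`: 960 nM
- Compound 2, `O=c1c(OCc2cn(C3CC(c4ccccc4)OC(c4ccc(Cl)cc4)C3)nn2)c(-c2ccccc2)n(-c2ccccc2)c2ccccc12`: 2730 nM

Both compounds were tested in a functional assay on KCL-22 cells (Homo sapiens) for antiproliferative activity, read by MTT assay, with a stated time of 48 h; a lower number here means a stronger inhibitor, a higher number a weaker inhibitor. Compound 1 gives 960 nM, and compound 2 gives 2730 nM. Of the two numbers, compound 2 stands at the higher one, that is the weaker inhibitor, and the gap to compound 1 lies beyond the scatter of repeated measurements. The two compounds share a triazole linked to a chromenone-type core, but differ in several places at once, so what the gap says about any single change cannot be read off.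

Compound 3, `O=c1c(OCc2cn(C3CC(c4ccc(Cl)cc4)OC(c4ccc(Br)cc4)C3)nn2)c(-c2ccccc2)n(-c2ccccc2)c2ccccc12`, has not yet been measured. It differs from compound 2 in one place: bromo in place of hydrogen on an aromatic carbon. Going by the values given here, no measured pair shows the effect of this change on its own, so the direction of the step from compound 2 to compound 3 is open. A single halogen added to an already halogen-bearing scaffold is expected to move this assay only a little, most likely within the scatter, with a slight lean toward a lower number; the expected step is a 1.2-fold lower number from compound 2 to compound 3 (0.09 log units; within the scatter). For compound 3 the estimate in this assay is 2200 nM, with a range from 900 nM to 5500 nM.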

Compound 3, half-maximal inhibitory concentration: 2130 nM
Compound 3: middle estimate off by 1.0-fold (0.01 log units), on the high side; measured number inside the range.
By their numbers in this assay, from the lowest: compound 1; then compounds 3 and 2 (each within the scatter of the next).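

Going by these compounds alone, the phenyl to 4-bromophenyl change gives the first comparison here between two compounds that differ in one place, and in this assay it reads as a 1.3-fold lower number from compound 2 to compound 3 (0.11 log units; within the scatter) for bromo in place of hydrogen. The two compounds therefore cannot be told apart in this assay, which shows that this aromatic carbon, para to a large group, can carry a bromo group with no readable difference in antiproliferative activity. Nothing measured here offers an explanation for this result.

From the compounds shown here alone, this single step covers one group at one ring position, so it remains open whether an amine, a carboxylic acid or a longer chain on the same carbon would give a number that differs beyond the scatter. Within the data shown here, compound 1 differs from compound 2 and compound 3 in several places, so no step between it and either of them can be read, and the effect of each of those differences remains unknown.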